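Swapping One Bromo for Hydrogen on Compound 2

The compounds below may be only part of what the source reports. "The series", "measured", "known", "first", "only" and "open" are said of these compounds alone.

In an ADME assay on HEK293 cells (Homo sapiens) for cytotoxicity, read by reporter gene assay and resazurin assay, with a stated time of 48 h (a lower number here means that less compound is tolerated, a higher number that more compound is tolerated), compound 1 `O=C(Nc1ccccc1)c1cc(Br)cc(Br)c1` gives > 100000 nM, which is a limit of the measurement and not a number. Compound 3 `COc1ccccc1C(=O)Nc1cccc(Cl)c1` gives > 100000 nM in this assay, and this too is a limit. The main feature of these data is thus (the limit of > 100000 nM in this assay, at which 2 of the 3 values shown sit). Within the data shown here, compound 2 `O=C(Nc1ccc(Sc2nc3ccccc3s2)c(Cl)c1)c1cccc(Br)c1O` gives 64000 nM, the only true number among the three, so it has no exact partner for comparison.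

Compound 4 `O=C(Nc1ccc(Sc2nc3ccccc3s2)c(Cl)c1)c1ccccc1O` differs from compound 2 in one place: hydrogen in place of bromo on an aromatic carbon. Hydrogen stands in place of bromo on an aromatic carbon, ortho to a hydroxy group and meta to a large group, so 3-bromo-2-hydroxyphenyl becomes 2-hydroxyphenyl.

Among the measured compounds shown here, no measured pair here shows what this swap does, so any forecast is cautious. Compound 2 gives 64000 nM, a measured number. Little room remains over it for a large rise to be seen as a number. The expected change, a 1.2-fold higher number from compound 2 to compound 4 (0.07 log units; within the scatter), is a step that stays within the usual scatter. Compound 4 could also read out only as a limit. For compound 4 the estimated value is 75000 nM, with an expected range from 38000 nM to 150000 nM.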

Compound 4, half-maximal cytotoxic concentration: 64000 nM
Beside the measured number, compound 4's estimate is 1.2-fold (0.07 log units) above it, and the stated range covers the measured number.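

In this assay, among these compounds, this is the first pair of compounds that differ in one place and both give true numbers, and the step reads no change at the digits printed from compound 2 to compound 4 (within the scatter). At this position, ortho to a hydroxy group and meta to a large group, hydrogen can thus stand in place of bromo with no difference that the assay can separate from its usual scatter: the 3-bromo-2-hydroxyphenyl and 2-hydroxyphenyl forms read alike here. The earlier compounds could not show this, because compound 2 was the only one with a true number and so had no exact partner, while the others gave only a limit: the limit of > 100000 nM in this assay, at which 2 of the 4 values shown sit.

Bromo and hydrogen are the only groups seen at this position, and how an amine or a carboxylic acid there would read remains open. On these data alone, it is also open whether this swap would read alike on a core that carries a methoxy group in place of the hydroxy group, or in a different assay.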